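Methoxy additions on the aryl ring of the dienone series

The compounds below may be only part of what the source reports. "The series", "measured", "known", "first", "only" and "open" are said of these compounds alone.

In a functional assay on IMR-32 cells (Homo sapiens) for cytotoxicity, read by sulforhodamine B assay, with a stated time of 48 h (on this read-out lower numbers stand for stronger inhibition and higher numbers for weaker inhibition), the measured compounds stand as follows:
compound 1 `CC1=C(/C=C/C(=O)/C=C/c2ccccc2)C(C)(C)CCC1` gives 20400 nM
compound 2 `COc1ccccc1/C=C/C(=O)/C=C/C1=C(C)CCCC1(C)C` gives 19200 nM
compound 3 `COc1ccc(/C=C/C(=O)/C=C/C2=C(C)CCCC2(C)C)cc1OC` gives 29200 nM

All three numbers lie within the scatter of one another; no order among them is claimed. Compound 3 stands on a core whose difference from compound 1 is not broken down here. Among the measured compounds shown here, the one counted step is a 1.1-fold lower number from compound 1 to compound 2 (0.03 log units; within the scatter), made by methoxy in place of hydrogen on an aromatic carbon.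

Compound 4 `COc1cc(/C=C/C(=O)/C=C/C2=C(C)CCCC2(C)C)cc(OC)c1OC` is not yet measured. It differs from compound 3 by methoxy in place of hydrogen on an aromatic carbon, the same kind of change as from compound 1 to compound 2, though the surroundings differ: in compound 2 the entering methoxy sits ortho to a large group, while in compound 4 it sits ortho to a methoxy group, meta to a large group and meta to a methoxy group.

For compound 4 the step is expected to be a 1.0-fold lower number from compound 3 to compound 4 (0.02 log units; within the scatter), an expectation resting on a 1.1-fold lower number from compound 1 to compound 2 (0.03 log units; within the scatter) and on the flatness of the three measured values. Compound 4 is estimated at 28000 nM, with a range from 12000 nM to 65000 nM.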

Compound 4, half-maximal inhibitory concentration: 55500 nM
The estimate for compound 4 lay 2.0-fold (0.30 log units) below the measured number; low and high end bracket the measured number.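

In this assay, the second use of methoxy in place of hydrogen on an aromatic carbon gives a 1.9-fold higher number from compound 3 to compound 4 (0.28 log units; within the scatter), and the two steps do not separate: the same change on two cores in this assay, a 1.1-fold lower number (0.03 log units; within the scatter) from compound 1 to compound 2 and a 1.9-fold higher number (0.28 log units; within the scatter) from compound 3 to compound 4, 2.0-fold (0.31 log units) apart, within the scatter of two such steps As far as these two pairs go, the change carries from one core to the other with no readable difference, and on neither core does it give a step beyond the scatter. Among the compounds shown here, this does not show that the change is without effect or that its size is independent of the core, since there are only two pairs and the surroundings of the entering methoxy differ between them, so core and place cannot be told apart.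

The compounds shown hold only hydrogen and methoxy on the aromatic ring, so how a hydroxyl, a fluorine or an amine would read there remains open. Also open, on these data alone, is whether a longer chain such as ethoxy, or a carboxylic acid, would give a step beyond the scatter on either core.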